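A few compounds are considered here, and "the series" means these few. Any claim that something is new, unique, unknown or untested is made for them only; others in the source may bear on it.

Compound 3 `COc1ccc(C(=O)NCCNc2cccc(NS(=O)(=O)c3cc(-c4cccc(C(=O)N(C)C)c4)ccc3OC)c2)cc1` gives 94% in a functional assay on CHO-K1 cells for agonist activity at Orexin receptor type 2 (Homo sapiens), read by calcium flux (a higher number here means a larger maximal response, a lower number a smaller maximal response), the highest of the two numbers reported. Compound 1 `COc1ccccc1C(=O)NCCNc1cccc(NS(=O)(=O)c2cc(-c3cccc(C(=O)N(C)C)c3)ccc2OC)c1` gives 74% in this assay, and compound 2 `COc1ccc(-c2cccc(C(=O)N(C)C)c2)cc1S(=O)(=O)Nc1cccc(NCCNC(=O)c2ccccc2)c1` is reported as "not active" (no number reported) in this assay, without a number. Among the compounds with values here, the one measured step, a number 20 percentage points higher from compound 1 to compound 3 (beyond the scatter), came with 4-methoxyphenyl in place of 2-methoxyphenyl on a carbonyl carbon. Compound 4 `COc1ccc(-c2cccc(C(=O)N(C)C)c2)cc1S(=O)(=O)Nc1cccc(NCCNC(=O)c2ccccc2Cl)c1` carries 2-chlorophenyl in place of 4-methoxyphenyl on a carbonyl carbon. That earlier step bears on it in reverse: the 2-methoxyphenyl of compound 1 and the unsubstituted phenyl of compound 2 both fall short of compound 3. A drop beyond the scatter is therefore expected in this assay, a number 34 percentage points lower from compound 3 to compound 4 (beyond the scatter). Compound 4 is estimated at 60%, within a range from 35% to 85%.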

Compound 4, largest response reached (Emax), in percent of the reference or control that the assay uses: 90%
The estimate for compound 4 lay 30 percentage points below the measured number; measured number above the stated range.
By their numbers in this assay, from the lowest: compound 1; then compounds 4 and 3 (each within the scatter of the next).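

In this assay, the 2-chlorophenyl group on this carbonyl carbon keeps the response of the 4-methoxyphenyl group, with a number 4 percentage points lower from compound 3 to compound 4 (within the scatter). Exchanging only the substituent of the 2-methoxyphenyl group, chloro in place of methoxy, gives a number 16 percentage points higher from compound 1 to compound 4 (beyond the scatter), so the response at this position depends on the substituent itself, not only on where it stands. No measured evidence here explains either step.

The compounds shown leave open how 4-chlorophenyl would behave. They also leave open whether a phenyl ring carrying an amine or a carboxylic acid would keep this response.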